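Benzyl Ether Variation on a Trimethoxyphenyl Isoflavone Scaffold

A few compounds are considered here, and "the series" means these few. Any claim that something is new, unique, unknown or untested is made for them only; others in the source may bear on it.

Compound 1, `COc1cc(OC)c(-c2coc3cc(OCc4ccccc4)ccc3c2=O)cc1OC`, gives 1640 nM.
Compound 2, `COc1ccc2c(=O)c(-c3cc(OC)c(OC)cc3OC)coc2c1`, gives 2640 nM.
Compound 3, `COc1cc(OC)c(-c2coc3cc(OCc4ccccc4F)ccc3c2=O)cc1OC`, gives 2100 nM.

These three compounds were compared in a functional assay on A-375 cells (Homo sapiens) for antiproliferative activity, read by MTT assay, with a stated time of 24 h; a higher number here means a weaker inhibitor, a lower number a stronger inhibitor. Compound 2 has the highest number of the three, yet its step to compound 3 and its step to compound 1 are both within the scatter, so no real separation among them is shown. The unmeasured compound 4, `COc1cc(OC)c(-c2coc3cc(OCc4ccccc4C(F)(F)F)ccc3c2=O)cc1OC`, differs from compound 2 in one place: 2-(trifluoromethyl)phenyl in place of hydrogen on a saturated chain carbon bound to an oxygen on an aromatic ring.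

Within the data shown here, two measured steps bear on this change. The step of a 1.6-fold higher number from compound 1 to compound 2 (0.21 log units; within the scatter) and the step of a 1.3-fold lower number from compound 2 to compound 3 (0.10 log units; within the scatter) both show that adding or removing a phenyl or a 2-fluorophenyl on the saturated chain carbon bound to an oxygen on the aromatic ring left the number within the scatter. The 2-(trifluoromethyl)phenyl group enters at the same place, so no step beyond the scatter is expected in this assay, with a slight lean toward a lower number because compound 3 gives 2100 nM. The expected step is a 1.3-fold lower number from compound 2 to compound 4 (0.12 log units; within the scatter). For compound 4, an estimate of 2000 nM is given, with a range from 900 nM to 4500 nM.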

Compound 4, half-maximal inhibitory concentration: > 10000 nM
Compound 4 gave a limit, no number; the forecaster's own chance of this, stated with the estimate: 3%; middle value at least 5.0-fold (0.69 log units) from the limit.
By their numbers in this assay, from the lowest: compounds 1, 3 and 2 (each within the scatter of the next). At a limit, above all of these: compound 4.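

Among these compounds, at the saturated chain carbon bound to an oxygen on an aromatic ring, the earlier compounds had stayed within the scatter, but in this assay 2-(trifluoromethyl)phenyl in place of hydrogen gives an at least 3.7-fold higher number from compound 2 to compound 4 (0.57 log units; beyond the scatter). The added ring alone does not account for this shift, since compound 1 and compound 3 also carry one: trifluoromethyl in place of fluoro gives an at least 4.7-fold higher number from compound 3 to compound 4 (0.67 log units; beyond the scatter), and trifluoromethyl in place of hydrogen gives an at least 6.0-fold higher number from compound 1 to compound 4 (0.78 log units; beyond the scatter). These steps are lower bounds, as compound 4 gave a limit and not a number: the limit of > 10000 nM in this assay, at which 1 of the 4 values shown sits.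

As far as these compounds go, how far the true value of compound 4 lies past that limit remains open. Also open, from the compounds shown here alone, is whether a chloro, a methyl or an amine in place of the trifluoromethyl would stay with compound 3 or go with compound 4.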